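A few compounds are considered here, and "the series" means these few. Any claim that something is new, unique, unknown or untested is made for them only; others in the source may bear on it.

Measured in a functional assay on DU-145 cells (Homo sapiens) for cytotoxicity, read by MTT assay; on this read-out lower numbers stand for stronger inhibition and higher numbers for weaker inhibition:
- compound 1 `COC(=O)C[C@H]1C[C@H](O)[C@@H](C)[C@@H](c2ccc(C)cc2)N1` gives 330000 nM
- compound 2 `COC(=O)C[C@H]1C[C@H](O)[C@@H](C)[C@@H](c2ccc(C(C)C)cc2)N1` gives 27400 nM
- compound 3 `COC(=O)C[C@H]1C[C@@H](O)[C@@H](C)[C@@H](c2ccc(OC)cc2)N1` gives 12600 nM

Compound 3 holds the lowest of these three numbers in this assay, and its gap to compound 2, its nearest neighbour, lies just beyond the scatter. Compound 4 `COC(=O)C[C@H]1C[C@H](O)[C@@H](C)[C@@H](c2ccc(OC)cc2)N1` is the counterpart of compound 3: the two compounds have the same atoms and bonds and differ only in configuration as drawn: 1 of 4 stereo elements differ; a stereocentre at a saturated ring carbon is drawn R in compound 3 and S in compound 4, a stereocentre at a saturated ring carbon drawn R in compound 3 and S in compound 4. At that carbon, compound 4 is drawn like compounds 1 and 2.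

Going by the values given here, the only measured step is a 12-fold lower number from compound 1 to compound 2 (1.08 log units; beyond the scatter), a large one, but it swaps methyl for isopropyl on an aromatic carbon. Among the compounds with values here, no measured pair therefore gauges a change of configuration directly. Compounds 1 and 2 both show higher numbers than compound 3, though they carry other aromatic groups, so only a moderate rise is expected. The estimated step is a 2.4-fold higher number from compound 3 to compound 4 (0.38 log units; beyond the scatter) with wide uncertainty. For compound 4 the expected value is 30000 nM, with an estimated range from 8000 nM to 120000 nM.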

Compound 4, half-maximal inhibitory concentration: 6500 nM
The estimate for compound 4 lay 4.6-fold (0.66 log units) above the measured number; measured number below the stated range.
By their numbers in this assay, from the lowest: compounds 4 and 3 (each within the scatter of the next); then compound 2; then compound 1.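

In this assay, changing the drawn configuration at a saturated ring carbon gives a 1.9-fold lower number from compound 3 to compound 4 (0.29 log units; within the scatter), so with methoxy on the aromatic carbon this configuration does not separate the pair. That reading rests on a clean comparison: the fact that compounds 3 and 4 differ only in the configuration as drawn. With the configuration of compounds 1 and 2 held, the aromatic substituent does separate the compounds, with methoxy in place of isopropyl giving a 4.2-fold lower number from compound 2 to compound 4 (0.62 log units; beyond the scatter) and methoxy in place of methyl giving a 51-fold lower number from compound 1 to compound 4 (1.71 log units; beyond the scatter).

The compounds shown leave open whether the same change of configuration would matter as little with isopropyl or methyl on the aromatic carbon. They also leave open how an amine or a trifluoromethyl group in place of methoxy would read out on these cells.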